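Methoxy in Place of Nitro on the Aromatic Ring

A few compounds are considered here, and "the series" means these few. Any claim that something is new, unique, unknown or untested is made for them only; others in the source may bear on it.

For the measured compounds named here, compound 3 `CC(C)C[C@H]1C[C@@H](Cl)C[C@@H](c2ccc([N+](=O)[O-])cc2)O1` gives 21000 nM in a functional assay on A2780 cells (Homo sapiens) for antiproliferative activity (a higher number here means a weaker inhibitor of growth, a lower number a stronger inhibitor of growth), the second highest of the three numbers so far. Its nearest neighbour is compound 2 `CC(C)C[C@H]1C[C@@H](Cl)C[C@@H](c2ccccc2)O1` at 17000 nM, and the furthest is compound 1 `CC(C)C[C@@H]1C[C@H](Cl)C[C@H](CC(C)C)O1` at 63000 nM. Between the first two lies a 1.2-fold higher number from compound 2 to compound 3 (0.09 log units; within the scatter). Compound 4 `COc1ccc([C@@H]2C[C@H](Cl)C[C@H](CC(C)C)O2)cc1` differs from compound 3 by methoxy in place of nitro on an aromatic carbon. Going by the values given here, the only measured step that touches this aromatic carbon, a 1.2-fold higher number from compound 2 to compound 3 (0.09 log units; within the scatter), was small, so another exchange of a group at the same place is expected to leave this assay about where it stands, with no step beyond the scatter. The estimate for compound 4 is 18000 nM, with a range of 8000 nM to 40000 nM, which means an expected step of a 1.2-fold lower number from compound 3 to compound 4 (0.07 log units; within the scatter).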

Compound 4, concentration for 50% growth inhibition: 25000 nM
For compound 4 the middle estimate is 1.4-fold (0.14 log units) below the measured one; measured number inside the range.
By their numbers in this assay, from the lowest: compounds 2, 3 and 4 (each within the scatter of the next); then compound 1.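

In this assay at this aromatic carbon, para to a large group, a 1.2-fold higher number from compound 3 to compound 4 (0.08 log units; within the scatter) and a 1.5-fold higher number from compound 2 to compound 4 (0.17 log units; within the scatter) both lie within the scatter. Hydrogen, nitro and methoxy therefore cannot be told apart here, so the flat result no longer rests on a single exchange. No evidence is available on the reason for this.

As far as these compounds go, it remains open whether an amine or a carboxylic acid on this carbon would move the number beyond the scatter. From the compounds shown here alone, whether methoxy would read the same on another carbon of the ring also remains open.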